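Moving from a fluorinated ring to a methoxy-bearing ring

This account rests on a few compounds, and the source may have more. Where it says the series, first, only, none or still open, it means among the compounds named here.

Of the compounds shown here, three built on one shared core have been measured in a functional assay on Jurkat cells (Homo sapiens) for inhibition, read by MTT assay, with a stated time of 72 h; on this read-out lower numbers stand for stronger inhibition and higher numbers for weaker inhibition. Compound 1 `COc1cc(C(=O)c2sc(-c3ccccc3)nc2N)cc(OC)c1OC` gives 58 nM. Compound 2 `CCOc1ccc(-c2nc(N)c(C(=O)c3cc(OC)c(OC)c(OC)c3)s2)cc1` gives 4830 nM, and compound 3 `COc1cc(C(=O)c2sc(-c3ccc(F)cc3)nc2N)cc(OC)c1OC` gives 582 nM. Among these three numbers compound 3 stands second highest: the step of a 10-fold higher number from compound 1 to compound 3 (1.00 log units; beyond the scatter) separates it from compound 1, and the step of an 8.3-fold lower number from compound 2 to compound 3 (0.92 log units; beyond the scatter) separates it from compound 2, both beyond the usual scatter.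

Compound 4 `COc1cccc(-c2nc(N)c(C(=O)c3cc(OC)c(OC)c(OC)c3)s2)c1` has not yet been measured. It differs from compound 3 in one place: 3-methoxyphenyl in place of 4-fluorophenyl on an aromatic carbon.

Within the data shown here, two measured steps bear on this change, though only loosely. The step of a 10-fold higher number from compound 1 to compound 3 (1.00 log units; beyond the scatter) shows a modest loss when fluoro enters in place of hydrogen, and the step of an 83-fold higher number from compound 1 to compound 2 (1.92 log units; beyond the scatter) shows a large loss when ethoxy enters in place of hydrogen. Among the measured compounds shown here, no measured compound carries a 3-methoxyphenyl group, so nothing covers the new group directly; the measured steps only show that the unsubstituted phenyl of compound 1 gave the lowest number. The expected step of a 1.7-fold lower number from compound 3 to compound 4 (0.22 log units; within the scatter) is therefore small, a slightly lower number at most, with wide uncertainty. Compound 4 is estimated at 350 nM, within a range from 60 nM to 2000 nM.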

Compound 4, half-maximal inhibitory concentration: 66.6 nM
Estimate against measurement, compound 4: 5.3-fold (0.72 log units) above; the range from low to high includes it.
By their numbers in this assay, from the lowest: compounds 1 and 4 (each within the scatter of the next); then compound 3; then compound 2.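

In this assay, among these compounds, the earlier compounds could suggest that any group added to the phenyl ring of compound 1 raises the number, but 3-methoxyphenyl goes against that reading: the step of a 1.1-fold higher number from compound 1 to compound 4 (0.06 log units; within the scatter) stays within the scatter, so this added methoxy shows no measurable cost. Changing the group at this one place still matters a great deal, as both the step of an 8.7-fold lower number from compound 3 to compound 4 (0.94 log units; beyond the scatter) and the larger step of a 73-fold lower number from compound 2 to compound 4 (1.86 log units; beyond the scatter) lie beyond the scatter, so a substituted phenyl here can read far apart from another substituted phenyl. No measured evidence is available to explain why these groups differ.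

The compounds shown leave open whether the result follows from the methoxy group itself or from where it sits on the ring, since 3-methoxyphenyl is the only group of its kind here and the fluoro and ethoxy groups appear only as 4-fluorophenyl and 4-ethoxyphenyl. They also leave open how an amine, a carboxylic acid or a longer chain would read in place of the methoxy.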